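The compounds below may be only part of what the source reports. "The series", "measured", "known", "first", "only" and "open" are said of these compounds alone.

Measured compounds:
Compound 1, `CCCCCCCCCCSC[C@H](NC(C)=O)C(=O)CCl`, gives 4700 nM in a functional assay on NALM-6 cells (Homo sapiens); on this read-out lower numbers stand for stronger inhibition and higher numbers for weaker inhibition.
Compound 2, `CCCCCCCCCCCCSC[C@H](NC(C)=O)C(=O)CCl`, gives 2000 nM in this assay.

Going by the values given here, compound 2 carries the lower of the two numbers so far, and its only neighbour for comparison is compound 1. Among the compounds with values here, the one measured step, a 2.4-fold lower number from compound 1 to compound 2 (0.37 log units; beyond the scatter), came from putting ethyl in place of hydrogen on a saturated chain carbon, ten or more bonds along the chain from a sulfur, and it lowered the number by a modest amount that still lies beyond the usual scatter.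

Compound 3, `CCCCCCCCCCCCCSC[C@H](NC(C)=O)C(=O)CCl`, has not yet been measured. It differs from compound 2 by methyl in place of hydrogen on a saturated chain carbon, ten or more bonds along the chain from a sulfur. The step from compound 1 to compound 2 is the only one that bears on this change, and it is of the same kind but larger, adding two chain carbons where compound 3 adds one. A lowering in the same direction is therefore expected in this assay, but smaller, and it may well stay within the scatter. Compound 3 is estimated at 1500 nM, with a range from 700 nM to 3500 nM. The expected step is a 1.3-fold lower number from compound 2 to compound 3 (0.12 log units; within the scatter).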

Compound 3, half-maximal inhibitory concentration: > 100000 nM
Compound 3 ended at the assay's limit (the forecaster's own chance of this, stated with the estimate: 5%); at least 66-fold (1.82 log units) between middle value and limit.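

In this assay compound 3 gives > 100000 nM, which is a limit of the assay and not a number: the limit of > 100000 nM in this assay, at which 1 of the 3 values shown sits.

This position therefore does not follow a smooth trend: lengthening the chain lowered the number from compound 1 to compound 2, but compound 3 goes against that direction, with an at least 50-fold higher number from compound 2 to compound 3 (1.69 log units; beyond the scatter) after only methyl in place of hydrogen. Compound 3 also falls well behind the shorter chain of compound 1, as an at least 21-fold higher number from compound 1 to compound 3 (1.32 log units; beyond the scatter) shows, so the added length does not simply return the activity to its earlier level but takes it out of the range that can be read in this assay.

The compounds shown cannot tell why so small a change has so large an effect, nor whether it reflects a real edge in chain length or something particular to compound 3. Going by these compounds, it remains open whether a longer chain also stays at the limit, and whether an amine or a carboxylic acid at the far end of the chain would restore a readable number.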